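The source may report more compounds than this note shows. Statements on the series, on what has been measured and on what is new or still open speak of the compounds shown alone.

The measured compounds so far:

Compound 1, `CCCCCn1c(CCC)nc2cc(NS(C)(=O)=O)ccc21`, in a functional assay on the whole organism with Rattus norvegicus as the target, read by paw edema, with a stated time of 5 h, at a dose of 40 mg/kg by the oral route (a lower number here means a weaker effect, a higher number a stronger effect of the compound at the dose given), compound 1 gives 95.6%.

Compound 2, `CCCCCCn1c(CCC)nc2cc(NS(C)(=O)=O)ccc21`, in this assay compound 2 gives 97.6%.

Among the measured compounds shown here, compound 2 holds the higher of the two numbers, yet its only neighbour, compound 1, sits within the scatter of it, so the two compounds cannot be ordered. For the measured compounds named here, the single measured step, a number 2 percentage points higher from compound 1 to compound 2 (within the scatter), lengthens the chain on the aromatic nitrogen and leaves the paw edema read-out essentially unchanged.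

Compound 3, `CCCCn1c(CCC)nc2cc(NS(C)(=O)=O)ccc21`, goes the other way along that same chain: hydrogen in place of ethyl on a saturated chain carbon, four bonds along the chain from an aromatic nitrogen. The step from compound 1 to compound 2 is the one that bears on this change, as it touches the same chain, and it stayed within the scatter. Because a number 2 percentage points higher from compound 1 to compound 2 (within the scatter) showed nothing beyond the scatter, shortening the chain is expected to show little as well, though the shortening is larger than the lengthening tested and in a direction not yet measured, so a small drop is estimated as a number 5.6 percentage points lower from compound 2 to compound 3 (within the scatter). Compound 3 is therefore estimated to give 92% in this assay, with an expected range from 76% to 100%.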

Compound 3, a percentage reported as activity, at one dose (the size of the read-out at that dose, not a potency): 92.7%
Compound 3: middle estimate off by 0.7 percentage points, on the low side; measured number inside the range.
By their numbers in this assay, from the lowest: compounds 3, 1 and 2 (each within the scatter of the next).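

Shortening the chain on the aromatic nitrogen now has a measured result. In this assay, hydrogen in place of ethyl, on a saturated chain carbon four bonds along the chain from an aromatic nitrogen, gives a number 4.9 percentage points lower from compound 2 to compound 3 (within the scatter) and hydrogen in place of methyl at that same place gives a number 2.9 percentage points lower from compound 1 to compound 3 (within the scatter) with neither step beyond the usual variation between repeats. The three chains on the nitrogen therefore cannot be told apart in this read-out, whereas the earlier compounds had shown this only for a single added methyl.

The compounds shown leave open how far this flat stretch extends, since a much shorter chain such as ethyl or methyl on the nitrogen, a longer chain, or a chain ending in a carboxylic acid or an amine could each depart from it. Each number is also the size of the effect at one dose and not a potency, so the three compounds could still differ at lower doses. Nothing available here bears on why the read-out stays level across these chains.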